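This account rests on a few compounds, and the source may have more. Where it says the series, first, only, none or still open, it means among the compounds named here.

Compound 1, `CN1C(=S)[C@@H](NC(=O)c2nc(Cc3ccccc3)n(C)n2)COc2ccccc21`, gives in a toxicity assay on HT-29 cells (Homo sapiens) for cytotoxicity (a lower number here means that less compound is tolerated, a higher number that more compound is tolerated), only a limit of the assay rather than a number: > 100000 nM.
Compound 2, `CC(C)n1nc(C(=O)N[C@H]2COc3ccccc3N(C)C2=S)nc1Cc1ccccc1`, likewise reaches only a limit of the assay: > 100000 nM.
Compound 3, `CN1C(=S)[C@@H](NC(=O)c2nc(Cc3ccccc3)n(CCCO)n2)COc2ccccc21`, also ends at a limit of the assay: > 100000 nM.

Compound 3 therefore stands nowhere on a scale: it is known only that it sits at the same limit as the other two compounds. The three steps that join the measured compounds are all hidden by these limits. The step that the two limits leave unreadable from compound 1 to compound 2 cannot be sized, the step that the two limits leave unreadable from compound 1 to compound 3 cannot be sized, and the step that the two limits leave unreadable from compound 2 to compound 3 cannot be sized either, because of the limit of > 100000 nM in this assay, at which 3 of the 3 values shown sit.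

Compound 4, `CN1C(=S)[C@@H](NC(=O)c2nc(Cc3ccccc3)n(C3CCOC3)n2)COc2ccccc21`, differs from compound 3 in one place: oxolan-3-yl in place of 3-hydroxypropyl on an aromatic nitrogen. Within the data shown here, no measured step bears on this change in a readable way, since every change made so far at this aromatic nitrogen left the value at the limit. The expectation is therefore that the step of a number no higher from compound 3 to compound 4 (the limit leaves the size open) amounts to nothing beyond the scatter. For compound 4 the estimate in this assay is 100000 nM, with a range from 40000 nM to 300000 nM, and most likely again only a limit will be reported.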

Compound 4, half-maximal cytotoxic concentration: > 100000 nM
Compound 4: a limit, no number (the forecaster's own chance of this, stated with the estimate: 85%); the middle value lies on the limit itself.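

Compound 4 ends at the same limit as compound 1, compound 2 and compound 3, so none of the steps joining it to those compounds can be read: the limit of > 100000 nM in this assay, at which 4 of the 4 values shown sit.

The compounds shown leave open where these four would fall on a real scale in this assay, and whether the different groups on the aromatic nitrogen separate them at all.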